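The source may hold more compounds than are shown below. What is called first, only, known or untested is meant among the compounds shown, and "the series" means these compounds.

Compound 1 `COc1ccc([C@H]2CC(=O)N(c3cccc(O)c3)C2)cc1OC1CCCC1`: > 10000 nM
Compound 2 `COc1ccc([C@H]2CC(=O)N(c3cccc(S(C)(=O)=O)c3)C2)cc1OC1CCCC1`: > 10000 nM

In a functional assay on HEK293 cells (Homo sapiens) for cytotoxicity (on this read-out lower numbers stand for higher toxicity in this test and higher numbers for lower toxicity in this test), compound 1 gives > 10000 nM, which is a limit and not a number. Compound 2 gives > 10000 nM, which is also a limit, so its true position is not known. For the measured compounds named here, the only measured step is a step that the two limits leave unreadable from compound 1 to compound 2. Compound 3 `COc1ccc([C@H]2CC(=O)N(c3cccc(NCC4CCOC4)c3)C2)cc1OC1CCCC1` has ((oxolan-3-yl)methyl)amino in place of methylsulfonyl on an aromatic carbon, meta to a large group: ((oxolan-3-yl)methyl)amino in place of methylsulfonyl on an aromatic carbon. Going by the values given here, no measured step tests this group, and the sole guide is the limit of > 10000 nM in this assay, at which 2 of the 2 values shown sit. Two different groups at this place leave this assay without a readable value, so no step beyond the scatter is expected, and no direction can be given. The step expected is a step that the limit leaves unreadable from compound 2 to compound 3. For compound 3 the estimated value is 15000 nM, with an expected range from 6000 nM to 50000 nM, and a report at the limit is likely.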

Compound 3, half-maximal cytotoxic concentration: > 10000 nM
Compound 3: only a limit was reported (the forecaster's own chance of this, stated with the estimate: 85%); the middle value does not contradict the limit.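

In this assay, for the compounds shown here, compound 3 gives > 10000 nM, which is a limit and not a number, so no step among compound 1, compound 2 and compound 3 can be read. The compounds shown leave open whether the hydroxy, methylsulfonyl and ((oxolan-3-yl)methyl)amino groups differ at all in this assay: the limit of > 10000 nM in this assay, at which 3 of the 3 values shown sit.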